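A few compounds are considered here, and "the series" means these few. Any claim that something is new, unique, unknown or untested is made for them only; others in the source may bear on it.

Notes on the series. Compound 1 `CC(C)c1noc(N2CCN(C(=O)[C@@H]3CCCN(S(=O)(=O)c4ccc(S(=O)(=O)C(C)C)cc4)C3)CC2)n1` is the reference point of the shared core. In a functional assay on MIA PaCa-2 cells (Homo sapiens) for inhibition, read by MTT assay, with a stated time of 3 days (on this read-out lower numbers stand for stronger inhibition and higher numbers for weaker inhibition), compound 1 gives > 10000 nM, which is a limit of the assay and not a number. Compound 2 `CCOC(=O)[C@@H]1CCCN(S(=O)(=O)c2ccc(S(=O)(=O)N(CC)CC)cn2)C1` gives in this assay > 10000 nM, again only a limit. Compound 3 `CCOC(=O)[C@@H]1CCCN(S(=O)(=O)c2ccc3cc(S(=O)(=O)N(CC)CC)ccc3c2)C1` gives in this assay > 10000 nM, likewise a limit. Among the measured compounds shown here, every value gathered so far therefore rests at the limit of > 10000 nM in this assay, at which 3 of the 3 values shown sit, so no step between measured compounds can be drawn, and compound 1 stands exactly where the other two stand: at the limit, with nothing to rank it against.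

Compound 4 `CC(C)c1noc(N2CCN(C(=O)[C@@H]3CCCN(S(=O)(=O)c4ccc(S(=O)(=O)NC5CCC5)cc4)C3)CC2)n1` is reached from compound 1 by one change, (cyclobutylamino in place of isopropyl on a sulfonyl sulfur), the same difference cut one bond further out reading isopropylsulfonyl to cyclobutylsulfamoyl. For the measured compounds named here, with only limits behind it, no measured step offers a direction for this change. The expected step is a step that the limit leaves unreadable from compound 1 to compound 4, which is none beyond the scatter. Compound 4 is estimated at 15000 nM, with a range of 4000 nM to 60000 nM, and most probably again only a limit.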

Compound 4, half-maximal inhibitory concentration: > 10000 nM
Compound 4 ended at the assay's limit (the forecaster's own chance of this, stated with the estimate: 75%); the middle value does not contradict the limit.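

No step can be read between compound 1 and compound 4, because both rest at a limit of the assay and not at a number: the limit of > 10000 nM in this assay, at which 4 of the 4 values shown sit. The compounds shown leave open whether any change to the shared core gives a measurable value in this assay at all.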